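Trifluoromethoxy for methylsulfonyl on the nitroaryl-type ring position

The compounds below may be only part of what the source reports. "The series", "measured", "known", "first", "only" and "open" are said of these compounds alone.

Measured compounds:
compound 1 `CN(C)CC[C@H](CSc1ccccc1)Nc1ccc(S(=O)(=O)NC(=O)c2ccc(N3CCN(CC4=C(c5ccc(Cl)cc5)CCC4)CC3)cc2)cc1[N+](=O)[O-]`: < 1 nM
compound 2 `CN(C)CC[C@H](CSc1ccccc1)Nc1ccc(S(=O)(=O)NC(=O)c2ccc(N3CCN(CC4=C(c5ccc(Cl)cc5)CCCCC4)CC3)cc2)cc1[N+](=O)[O-]`: < 1 nM
compound 3 `CN(C)CC[C@H](CSc1ccccc1)Nc1ccc(S(=O)(=O)NC(=O)c2ccc(N3CCN(Cc4ccccc4-c4ccc(Cl)cc4)CC3)cc2)cc1S(C)(=O)=O`: < 1 nM

In an assay on isolated protein for displacement of a labelled ligand from Bcl2-associated agonist of cell death (Homo sapiens), read by fluorescence polarization (a higher number here means a weaker inhibitor, a lower number a stronger inhibitor), compound 1 gives < 1 nM, which is a limit of the assay and not a number. Compound 2 likewise gives < 1 nM in this assay, again a limit. Compound 3 gives < 1 nM in this assay, also a limit. All three measured values therefore sit at the same floor, as noted in the limit of < 1 nM in this assay, at which 3 of the 3 values shown sit, and no ordering among compounds 1, 2 and 3 can be read from them. Compound 3 thus stands at the limit of this assay, not above or below any other measured compound.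

Compound 4 `CN(C)CC[C@H](CSc1ccccc1)Nc1ccc(S(=O)(=O)NC(=O)c2ccc(N3CCN(Cc4ccccc4-c4ccc(Cl)cc4)CC3)cc2)cc1OC(F)(F)F` is not yet measured. It differs from compound 3 by trifluoromethoxy in place of methylsulfonyl on an aromatic carbon. Within the data shown here, no step between measured compounds is available to calibrate this change. Given that compound 3 sits at the limit of this assay, the expected step from compound 3 to compound 4 is a step that the limit leaves unreadable from compound 3 to compound 4, no movement beyond the scatter, with the chance that compound 4 again returns only a limit. Compound 4 is estimated at 0.8 nM in this assay, in the range 0.2 nM to 3 nM.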

Compound 4, inhibition constant: < 1 nM
Compound 4 gave a limit, no number; the forecaster's own chance of this, stated with the estimate: 60%; the middle value is on the limit's open side.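

In this assay compound 4 gives < 1 nM, a limit of the assay and not a number. Compound 3 stands at the same limit, so no step can be read between compound 3 and compound 4: the limit of < 1 nM in this assay, at which 4 of the 4 values shown sit.

The compounds shown leave open whether trifluoromethoxy and methylsulfonyl on this aromatic carbon differ at all in this assay.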